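From pyridin-3-yl to 2-methylphenyl on a shared core

The source may report more compounds than this note shows. Statements on the series, on what has been measured and on what is new or still open speak of the compounds shown alone.

Values from a physicochemical assay for solubility (on this read-out higher numbers stand for higher solubility and lower numbers for lower solubility), follow, and each one is a limit of the assay rather than a number:

- Compound 1 `CNC(=O)c1cc(C(=O)N[C@H]2[C@@H]3COC[C@@H]32)cc2c1OC[C@H]2c1cccnc1` gives >= 104 ug/mL as its limit
- Compound 2 `CNC(=O)c1cc(C(=O)NC2CC2)cc2c1OC[C@H]2c1cccc(F)c1` gives >= 175 ug/mL as its limit
- Compound 3 `CNC(=O)c1cc(C(=O)NC)c2c(c1)[C@H](c1ccccc1)[C@@H](CF)O2` gives >= 149 ug/mL as its limit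

Compound 1 has no exact number, and its place on the scale is the limit of >= 104 ug/mL in this assay, at which 1 of the 3 values shown sits, in a set where every entry is a limit.

Compound 4 `CNC(=O)c1cc(C(=O)N[C@H]2[C@@H]3COC[C@@H]32)cc2c1OC[C@H]2c1ccccc1C` keeps the core of compound 1 and alters one group. The change, 2-methylphenyl in place of pyridin-3-yl on a saturated ring carbon puts 2-methylphenyl in place of pyridin-3-yl on a saturated ring carbon.

Going by the values given here, no two measured compounds differ in one place only, so the data give no direct size for this swap. With no number for compound 1, any step from it can only be rough. The expectation leans on compound 2, which reports >= 175 ug/mL as a limit. It also leans on compound 3, which reports >= 149 ug/mL as a limit. The expected change in this assay is an at least 1.1-fold lower number from compound 1 to compound 4 (0.06 log units; that floor lies within the scatter) as a small downward step that should stay within the scatter. The estimate for compound 4 is 90 ug/mL (35 ug/mL to 190 ug/mL).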

Compound 4, solubility: >= 103 ug/mL
Compound 4: a limit, no number; the forecaster's own chance of this, stated with the estimate: 50%; middle value at least 1.1-fold (0.05 log units) from the limit.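

In this assay compound 4 gives >= 103 ug/mL, which is a limit and not a number. Compound 1 gives >= 104 ug/mL, which is also a limit, so no step can be read from compound 1 to compound 4. The compounds shown leave open whether 2-methylphenyl in place of pyridin-3-yl changes this read-out at all.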